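This account rests on a few compounds, and the source may have more. Where it says the series, first, only, none or still open, it means among the compounds named here.

Measured in a functional assay on MGC-803 cells (Homo sapiens) for cytotoxicity, read by MTT assay, with a stated time of 72 h; a higher number here means a weaker inhibitor, a lower number a stronger inhibitor:
- compound 1 `C=C1C(=O)[C@@]23C(=O)OC[C@]4(C(=O)CCC(C)(C)[C@H]4C=O)[C@@H]2CC[C@@H]1[C@H]3OC(C)=O`: 1660 nM
- compound 2 `C=C1C(=O)[C@@]23C(=O)OC[C@]4(C(=O)CCC(C)(C)[C@H]4C=O)[C@@H]2CC[C@@H]1[C@H]3OC(=O)c1ccc(C(F)(F)F)cc1`: 4930 nM

Of the two, compound 2 has the higher number, which makes it the weaker inhibitor. Compound 3 `C=C1C(=O)[C@@]23C(=O)OC[C@]4(C(=O)CCC(C)(C)[C@H]4C=O)[C@@H]2CC[C@@H]1[C@H]3OC(=O)c1ccccc1Cl` keeps the shared core and changes one group: 2-chlorophenyl in place of 4-(trifluoromethyl)phenyl on a carbonyl carbon. For the measured compounds named here, one measured step bears on this place, a 3.0-fold higher number from compound 1 to compound 2 (0.47 log units; beyond the scatter), and it is modest. It shows that the smaller methyl group gave the lower number, but no chlorine-bearing ring has been measured here. A modest drop is therefore expected, with real uncertainty. The estimated change is a 1.6-fold lower number from compound 2 to compound 3 (0.22 log units; within the scatter). For compound 3 the expected value is 3000 nM, within an estimated range of 1200 nM to 7500 nM.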

Compound 3, half-maximal inhibitory concentration: 2660 nM
Compound 3: middle estimate off by 1.1-fold (0.05 log units), on the high side; measured number inside the range.
By their numbers in this assay, from the lowest: compounds 1, 3 and 2 (each within the scatter of the next, the first and the last beyond it).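

In this assay, swapping one aromatic ring for another on this carbonyl carbon gives no separable difference (a 1.9-fold lower number from compound 2 to compound 3 (0.27 log units; within the scatter)). The 2-chlorophenyl group also cannot be told apart from methyl (a 1.6-fold higher number from compound 1 to compound 3 (0.20 log units; within the scatter)), so an aromatic ring at this place does not by itself set compound 3 apart from compound 1, even though compound 2 is set apart. Nothing available explains these results.

As far as these compounds go, it remains open how an amine or a carboxylic acid on the aromatic ring would behave. A longer chain in place of methyl is also untested by these compounds.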